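Lipophilicity notes on a hydroxyalkyl aryl ether series

The source may hold more compounds than are shown below. What is called first, only, known or untested is meant among the compounds shown, and "the series" means these compounds.

compound 1 `Cc1ccccc1OCC(C)O`: 2.14
compound 2 `CC(O)COc1ccc(Cl)cc1Cl`: 2.75
compound 3 `Cc1cc(Cl)c(OCCCO)c(Cl)c1`: 3.36

In a physicochemical assay for lipophilicity, measured as octanol-water partition (on this read-out higher numbers stand for higher lipophilicity and lower numbers for lower lipophilicity), compound 3 gives 3.36, the highest of the three measured values. Compound 2 is the nearest to it, lower by more than the scatter, and compound 1 lies further below, also beyond the scatter. Compound 4 `Cc1cc(Cl)c(OCC(C)O)c(Cl)c1` is not yet measured. It differs from compound 3 by 1-hydroxyethyl in place of 2-hydroxyethyl on a saturated chain carbon bound to an oxygen on an aromatic ring. The two compounds have the same atoms, joined differently; cut one bond further out, the change reads 3-hydroxypropyl to 2-hydroxypropyl. Within the data shown here, no measured pair in the set shows this step, so its size must be judged from the change alone. A small step, upward if any and within the usual scatter, is expected: a number 0.09 log units higher from compound 3 to compound 4 (within the scatter). Compound 4 is estimated at 3.45, between 3.15 and 3.75.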

Compound 4, partition coefficient: 3.16
Compound 4: middle estimate off by 0.29 log units, on the high side; the range from low to high includes it.
By their numbers in this assay, from the lowest: compound 1; then compound 2; then compounds 4 and 3 (each within the scatter of the next).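

In this assay, among these compounds, the change from 3-hydroxypropyl to 2-hydroxypropyl on the shared core gives the first single-place step: a number 0.20 log units lower from compound 3 to compound 4 (within the scatter). At this position, then, joining the same atoms differently leaves compound 3 and compound 4 unresolved on this read-out. Nothing available explains the step.

Going by these compounds, whether the same change stays as small on the cores of compound 1 and compound 2 remains open. Also open, on these data alone, is how a longer chain or an amine would read at this place.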